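The source may hold more compounds than are shown below. What is called first, only, known or untested is meant among the compounds shown, and "the series" means these compounds.

In a functional assay on KB cells (Homo sapiens) for antiproliferative activity, read by sulforhodamine B assay, with a stated time of 3 days (a higher number here means that more compound is needed for the effect, a lower number that less compound is needed), compound 1 (`CCC1=C(O)c2c(oc(-c3ccc(COC)cc3)cc2=O)C(CC)(CC)C1=O`) reports only a limit, > 52.4 uM. Compound 2 (`CCC1=C(O)c2c(oc(-c3cccc(OC)c3)cc2=O)C(CC)(CC)C1=O`) gives 13.3 uM and compound 3 (`CCC1=C(O)c2c(oc(-c3ccc(OC)cc3C)cc2=O)C(CC)(CC)C1=O`) gives 20.9 uM, two values within the scatter of each other. Compound 4 (`CCC1=C(O)c2c(oc(-c3ccc(OC)c(C)c3C)cc2=O)C(CC)(CC)C1=O`) departs from compound 3 by methyl in place of hydrogen on an aromatic carbon. For the measured compounds named here, no measured pair isolates this change. The closest guide is a 1.6-fold higher number from compound 2 to compound 3 (0.20 log units; within the scatter), which stays within the scatter, whereas the larger at least 3.9-fold lower number from compound 1 to compound 2 (0.59 log units; beyond the scatter) and an at least 2.5-fold lower number from compound 1 to compound 3 (0.39 log units; beyond the scatter) both start from a limit and involve the 4-(methoxymethyl)phenyl group. An estimated 1.0-fold lower number from compound 3 to compound 4 (0.02 log units; within the scatter) is therefore expected, with no shift beyond the scatter in either direction. Compound 4 is expected at 20 uM, with an estimated range of 9 uM to 45 uM.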

Compound 4, concentration for half-maximal effect: 5.43 uM
Compound 4: the middle estimate sits 3.7-fold (0.57 log units) above what was measured, and the stated range ends above it.
By their numbers in this assay, from the lowest: compound 4; then compounds 2 and 3 (each within the scatter of the next). At a limit, above all of these: compound 1.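

In this assay methyl in place of hydrogen, ortho to a methoxy group and ortho to a methyl group, gives a 3.8-fold lower number from compound 3 to compound 4 (0.59 log units; beyond the scatter) and so takes the number beyond the scatter. Unlike the earlier steps beyond the scatter, this one starts from a measured value, not a limit, and it shows that this position responds to a single added methyl. Nothing given here accounts for the step.

On these data alone, whether ethyl, chlorine or an amine at this position would act like methyl stays open. So does whether the new methyl would have the same effect without the methyl already present in compound 3.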